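A few compounds are considered here, and "the series" means these few. Any claim that something is new, unique, unknown or untested is made for them only; others in the source may bear on it.

Compound 1, `CCOC(=O)CCCCCOc1cccc(CN(C(=O)c2ccc(-c3cccc(N(C)C)c3)cc2)C(C)C)c1`: > 26000 nM, a limit of the assay.
Compound 2, `CCOC(=O)CCCCCOc1cccc(CN(C(=O)c2ccc(-c3cccc(Oc4ccccc4)c3)cc2)C(C)C)c1`: > 19600 nM, a limit of the assay.
Compound 3, `CCOC(=O)CCCCCOc1cccc(CN(C(=O)c2ccc(-c3cccc(O)c3)cc2)C(C)C)c1`: > 26000 nM, a limit of the assay.

All three measured compounds share one core and differ only in the group on the outer aromatic ring. In an ADME assay on BJ cells (Homo sapiens) for cytotoxicity, read by CellTiter-Glo and resazurin assay, with a stated time of 72 h (a lower number here means that less compound is needed, a higher number that more compound is needed for the effect), none of them reaches a measurable number: the values sit at the limit of > 19600 nM in this assay, at which 1 of the 3 values shown sits, and at the limit of > 26000 nM in this assay, at which 2 of the 3 values shown sit. Compound 3 therefore stands at a limit, and it cannot be placed above or below compound 1 or compound 2 on the numbers shown. The measured steps tell the same story: a step that the two limits leave unreadable from compound 1 to compound 2, a step that the two limits leave unreadable from compound 1 to compound 3 and a step that the two limits leave unreadable from compound 2 to compound 3 are all unreadable, because both ends of each lie at a limit.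

Compound 4, `CCOC(=O)CCCCCOc1cccc(CN(C(=O)c2ccc(-c3cccc(CC(=O)O)c3)cc2)C(C)C)c1`, carries the change (carboxymethyl in place of hydroxy on an aromatic carbon). Among the compounds with values here, no measured step bears readably on it; the only guidance is that three different groups at this position all left this assay at its limit. The step from compound 3 to compound 4 is therefore expected to be a number no higher from compound 3 to compound 4 (the limit leaves the size open), with compound 4 expected to come out at 26000 nM, between 13000 nM and 60000 nM.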

Compound 4, half-maximal effective concentration: > 26000 nM
Compound 4: a limit, no number; the forecaster's own chance of this, stated with the estimate: 85%; the middle value lies on the limit itself.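

Within the data shown here, compound 4, like compound 1, compound 2 and compound 3, stands at a limit in this assay, so no step from any of them to compound 4 can be read. The compounds shown leave open at what concentration, if any, each of the four would reach the effect.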